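Oxolan-3-yl in place of oxan-3-yl: what to expect

This account rests on a few compounds, and the source may have more. Where it says the series, first, only, none or still open, it means among the compounds named here.

In an ADME assay on MDCKII-LE cells (Canis lupus familiaris) for permeability, read by transwell migration, in the apical to basolateral direction (on this read-out lower numbers stand for lower permeability and higher numbers for higher permeability), compound 1 (`NC(=O)[C@@H](CCC(F)(F)F)N(CC1COC1)S(=O)(=O)c1ccc(Cl)cc1`) gives 25.4 10^-6 cm/s and compound 2 (`NC(=O)[C@@H](CCC(F)(F)F)N(C[C@H]1CCCOC1)S(=O)(=O)c1ccc(Cl)cc1`) gives 18.2 10^-6 cm/s. Among the measured compounds shown here, compound 2 therefore stands within the scatter of compound 1, the only other measured compound, and the two cannot be ranked. Compound 3 (`NC(=O)[C@@H](CCC(F)(F)F)N(C[C@@H]1CCOC1)S(=O)(=O)c1ccc(Cl)cc1`) has yet to be measured in this assay. It departs from compound 2 in one place: oxolan-3-yl in place of oxan-3-yl on a saturated chain carbon bound to a sulfonamide nitrogen. In words, this is oxolan-3-yl in place of oxan-3-yl on a saturated chain carbon bound to a sulfonamide nitrogen.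

For the measured compounds named here, one measured step bears on this change: a 1.4-fold lower number from compound 1 to compound 2 (0.14 log units; within the scatter), with oxan-3-yl in place of oxetan-3-yl at that same place. This step lies within the scatter. Going by the values given here, no measured compound carries oxolan-3-yl, so the evidence is thin, and no shift beyond the scatter is expected in this assay. The expected step is a 1.2-fold higher number from compound 2 to compound 3 (0.06 log units; within the scatter), and its direction is not secure. Compound 3 is estimated at 21 10^-6 cm/s, with an expected range from 12 10^-6 cm/s to 34 10^-6 cm/s.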

Compound 3, apparent permeability: 20.5 10^-6 cm/s
Estimate against measurement, compound 3: 1.0-fold (0.01 log units) above; the measured number falls inside the stated range.
By their numbers in this assay, from the lowest: compounds 2, 3 and 1 (each within the scatter of the next).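

In this assay, the ring change at this place gives a 1.1-fold higher number from compound 2 to compound 3 (0.05 log units; within the scatter), and set against the oxetan-3-yl of compound 1 it gives a 1.2-fold lower number from compound 1 to compound 3 (0.09 log units; within the scatter). Both steps lie within the scatter, so all three pairs among these compounds can now be read, and oxetan-3-yl, oxan-3-yl and oxolan-3-yl on a saturated chain carbon bound to a sulfonamide nitrogen cannot be told apart on this read-out, where the earlier pair alone had only compared the first two of these rings. The data offer no measured property or other independent finding that would account for this flat picture.

All three compounds carry a saturated oxygen-containing ring at this place, so they leave open whether an amine or a carboxylic acid there would move the number beyond the scatter. They also leave open whether the other configuration at the defined ring stereocentre of compound 2 or compound 3 would read the same.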